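A Second Methyl, Placed on the Other Arm

The source may hold more compounds than are shown below. What is called first, only, known or untested is meant among the compounds shown, and "the series" means these compounds.

Compound 2 `CCCc1cc(N)c2cc(NC(=O)/C=C/c3ccc(CC)cc3)ccc2n1` and compound 1 `CCCc1ccc(/C=C/C(=O)Nc2ccc3nc(CCC)cc(N)c3c2)cc1` share a core and differ in one place: methyl in place of hydrogen on a saturated chain carbon, two bonds along the chain from an aromatic carbon, which read one bond further out turns the ethyl into a propyl on the phenyl. In a functional assay on HEK293 cells for activation of melanin-concentrating hormone receptor 1 (Homo sapiens), read by inositol phosphate accumulation (a lower number here means that less compound is needed, a higher number that more compound is needed for the effect), compound 2 gives 160 nM, while compound 1 gives 3600 nM; the step is a 23-fold higher number from compound 2 to compound 1 (1.35 log units; beyond the scatter). Compound 3 `CC(C)c1cc(N)c2cc(NC(=O)/C=C/c3ccc(C(F)(F)F)cc3)ccc2n1` carries a trifluoromethyl on the phenyl and an isopropyl on the core; how its core differs from that of compound 2 is not broken down here. In this assay compound 3 gives 160 nM, level with compound 2. Compound 4 `CCC(C)c1cc(N)c2cc(NC(=O)/C=C/c3ccc(C(F)(F)F)cc3)ccc2n1` differs from compound 3 by methyl in place of hydrogen on a saturated chain carbon, two bonds along the chain from an aromatic carbon, the same change made twice in this set, here turning isopropyl into sec-butyl. The earlier step of a 23-fold higher number from compound 2 to compound 1 (1.35 log units; beyond the scatter) was large, but this change sits on the core rather than the phenyl, so a smaller rise is expected: a 3.1-fold higher number from compound 3 to compound 4 (0.49 log units; beyond the scatter). Compound 4 is therefore estimated at 500 nM, between 150 nM and 2500 nM.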

Compound 4, half-maximal effective concentration: 44 nM
For compound 4 the middle estimate is 11-fold (1.06 log units) above the measured one; measured number below the stated range.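

Adding the methyl to the isopropyl of compound 3 moves the reading in this assay down, giving a 3.6-fold lower number from compound 3 to compound 4 (0.56 log units; beyond the scatter). Set beside the earlier step, the same change does not carry over from one core to the other, and its direction reverses: the same change on two cores in this assay, a 23-fold higher number (1.35 log units; beyond the scatter) from compound 2 to compound 1 and a 3.6-fold lower number (0.56 log units; beyond the scatter) from compound 3 to compound 4, 82-fold (1.91 log units) apart, beyond the scatter of two such steps. Within the data shown here, with only two pairs, this does not show what separates them, as the change extends the ethyl on the phenyl in one pair and the isopropyl on the core in the other, and the pairs also differ elsewhere.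

As far as these compounds go, it remains open whether turning isopropyl into sec-butyl would lower the number with ethyl rather than trifluoromethyl on the phenyl. From the compounds shown here alone, it also remains open how a longer chain in place of the sec-butyl would read.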